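The compounds below may be only part of what the source reports. "The series", "measured", "known", "first", "only" and "open" are said of these compounds alone.

Measured so far:
compound 1 `FC(F)(F)CCCCOc1ccc(-c2nnn(CCCCc3nnn[nH]3)n2)cc1`, in a functional assay (Cavia porcellus) for antagonist activity at cysteinyl leukotriene receptor (Homo sapiens) (a higher number here means a more potent compound, by a factor of ten per unit of this negative logarithm, a lower number a less potent compound), compound 1 gives 5.92;
compound 2 `CCCOc1ccc(-c2nnn(CCCCc3nnn[nH]3)n2)cc1`, in this assay compound 2 gives 5.52;
compound 3 `c1ccc(CCCCOc2ccc(-c3nn[nH]n3)cc2)cc1`, in this assay compound 3 gives 5.92.

Compound 3 stands level with compound 1 at the digits shown, the two together at the top of the three numbers, while compound 2 lies lower. Compound 4 `N#CNC(=O)CCCCn1nnc(-c2ccc(OCCCCc3ccccc3)cc2)n1` carries 4-(cyanocarbamoyl)butyl in place of hydrogen on an aromatic nitrogen. Going by the values given here, the single measured step, a number 0.40 log units lower from compound 1 to compound 2 (beyond the scatter), concerns a saturated chain carbon three bonds along the chain from the ring oxygen, not the aromatic nitrogen, so no measured step bears directly on this change. What the numbers do show is that compound 1, whose aromatic nitrogen bears a large group, and compound 3, whose aromatic nitrogen bears hydrogen, give the same value. On that basis the expected step is a number 0.18 log units higher from compound 3 to compound 4 (within the scatter), a change within the scatter. Compound 4 is estimated at 6.1, within 5.4 to 6.9.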

Compound 4, negative logarithm of the antagonist equilibrium constant: 6.1
Beside the measured number, compound 4's estimate shows no gap at the digits printed; low and high end bracket the measured number.
By their numbers in this assay, from the lowest: compound 2; then compounds 1, 3 and 4 (each within the scatter of the next).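

In this assay, going by these compounds alone, 4-(cyanocarbamoyl)butyl in place of hydrogen on an aromatic nitrogen gives a number 0.18 log units higher from compound 3 to compound 4 (within the scatter) and is the first step read directly at this position. It shows that this nitrogen can carry a group of this size, with its nine heavy atoms, without a change beyond the scatter. Nothing at hand explains this result. The compounds shown leave open how a plain butyl chain or a carboxylic acid at the end of that chain would read on this nitrogen. On these data alone, a shorter or longer chain ending in the cyanocarbamoyl group also remains open.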